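Swapping the aryl group from compound 3 to compound 4

This account rests on a few compounds, and the source may have more. Where it says the series, first, only, none or still open, it means among the compounds named here.

Measured in a functional assay on DU-145 cells (Homo sapiens) for inhibition, read by trypan blue exclusion, with a stated time of 72 h; on this read-out lower numbers stand for stronger inhibition and higher numbers for weaker inhibition:
compound 1 `Cn1c(=O)c(S(=O)(=O)c2ccc(F)cc2F)cc2cnc(Nc3ccc4occc4c3)nc21`: 15000 nM
compound 2 `Cn1c(=O)c(S(=O)(=O)c2ccc(F)cc2F)cc2cnc(Nc3ccccn3)nc21`: 75000 nM
compound 3 `Cn1c(=O)c(S(=O)(=O)c2ccc(F)cc2F)cc2cnc(Nc3ccc4cccc(O)c4n3)nc21`: 5000 nM

Of the three measured compounds, compound 3 carries the lowest number in this assay. The next compound is compound 4 `Cc1cc2cc(Nc3ncc4cc(S(=O)(=O)c5ccc(F)cc5F)c(=O)n(C)c4n3)ccc2[nH]1`, which has not yet been measured. It has 2-methyl-1H-indol-5-yl in place of 8-hydroxyquinolin-2-yl on a nitrogen on an aromatic ring. Three measured steps change this same group. The modest one, a 5.0-fold higher number from compound 1 to compound 2 (0.70 log units; beyond the scatter), separates the two compounds without 8-hydroxyquinolin-2-yl. Arrival of that group gave a modest 3.0-fold lower number from compound 1 to compound 3 (0.48 log units; beyond the scatter) and a large 15-fold lower number from compound 2 to compound 3 (1.18 log units; beyond the scatter). For the measured compounds named here, no measured compound carries 2-methyl-1H-indol-5-yl, so the comparison is indirect. By name, the closest measured group is the 1-benzofuran-5-yl of compound 1, which stands at 15000 nM. Losing 8-hydroxyquinolin-2-yl is therefore expected to give a modest rise, and the expected step is a 2.0-fold higher number from compound 3 to compound 4 (0.30 log units; within the scatter). The estimated value for compound 4 is 10000 nM, with an expected range from 3500 nM to 30000 nM.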

Compound 4, half-maximal inhibitory concentration: 750 nM
Compound 4: the middle estimate sits 13-fold (1.12 log units) above what was measured; the whole stated range lies above it.
By their numbers in this assay, from the lowest: compound 4; then compound 3; then compound 1; then compound 2.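

Working notes on this position: in this assay, the aryl group on the nitrogen can go beyond the level reached with 8-hydroxyquinolin-2-yl, as 2-methyl-1H-indol-5-yl gives the lowest number of the series (a 6.7-fold lower number from compound 3 to compound 4 (0.82 log units; beyond the scatter)). The span across this position also widens (a 100-fold lower number from compound 2 to compound 4 (2.00 log units; beyond the scatter)), and 1-benzofuran-5-yl proves a poor guide to 2-methyl-1H-indol-5-yl despite the similar names (a 20-fold lower number from compound 1 to compound 4 (1.30 log units; beyond the scatter)). No supporting data explain these differences.

The compounds shown do not separate the part played by the methyl from that of the indole ring with its hydrogen on nitrogen. Going by these compounds, it also remains open whether the low number survives when the methyl is replaced by an ethyl, a methoxy group or a dimethylaminomethyl chain.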